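Benzoyl exchange on the acylhydrazone: cytotoxicity notes

This account rests on a few compounds, and the source may have more. Where it says the series, first, only, none or still open, it means among the compounds named here.

Compound 1 `CC(/C=N/Nc1ccc([N+](=O)[O-])cc1)=N\NC(=O)c1ccccc1F` carries a 2-fluorophenyl on the carbonyl carbon. In an ADME assay on J774 cells (Mus musculus, strain BALB/c) for cytotoxicity, read by resazurin assay, with a stated time of 72 h (on this read-out higher numbers stand for lower toxicity in this test and lower numbers for higher toxicity in this test), compound 1 gives > 100000 nM, a limit of the assay rather than a number. Compound 2 `CC(/C=N/Nc1ccc([N+](=O)[O-])cc1)=N\NC(=O)c1ccccc1Oc1ccccc1` has phenoxy in place of fluoro on an aromatic carbon. In this assay compound 2 gives > 100000 nM, again a limit. The step that the two limits leave unreadable from compound 1 to compound 2 is therefore of unreadable size. Both values sit at one limit (the limit of > 100000 nM in this assay, at which 2 of the 2 values shown sit), so compound 1 stands nowhere more precisely than at that limit.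

Compound 3 `COc1ccc(C(=O)N/N=C(C)/C=N/Nc2ccc([N+](=O)[O-])cc2)cc1` differs from compound 1 by 4-methoxyphenyl in place of 2-fluorophenyl on a carbonyl carbon. For the measured compounds named here, the only measured step, from compound 1 to compound 2, alters the same part of the molecule and gives no readable size, so no direction beyond the scatter can be derived. For compound 3 the estimate in this assay is 150000 nM, expected between 60000 nM and 400000 nM. The step that the limit leaves unreadable from compound 1 to compound 3 is expected to stay within the scatter, most likely again as a limit.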

Compound 3, half-maximal cytotoxic concentration: > 100000 nM
Compound 3: no number, only a limit (the forecaster's own chance of this, stated with the estimate: 85%); the middle value does not contradict the limit.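

Compound 3, like compound 1 and compound 2, gives only a limit, so no step among them can be read: the limit of > 100000 nM in this assay, at which 3 of the 3 values shown sit.

The compounds shown leave open whether any exchange on the carbonyl carbon gives a readable number in this assay.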